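The source may hold more compounds than are shown below. What is called first, only, known or untested is meant among the compounds shown, and "the series" means these compounds.

Measured in a functional assay on HL-60 cells (Homo sapiens) for cytotoxicity, read by luminescence and CellTiter-Glo, with a stated time of 3 days; on this read-out higher numbers stand for weaker inhibition and lower numbers for stronger inhibition:
Compound 1 `N#Cc1ccc(NC(=O)c2c(O)cccc2F)cc1`: > 10000 nM
Compound 2 `O=C(Nc1cc(C(F)(F)F)cc(C(F)(F)F)c1)c1cc(Cl)c(-c2ccccc2)cc1O`: 790 nM

Compound 1 gives > 10000 nM in this assay, which is a limit of the assay and not a number. Compound 3 `COc1cccc(O)c1C(=O)Nc1ccc(C#N)cc1` keeps the core of compound 1 but carries methoxy in place of fluoro on an aromatic carbon, ortho to a large group and meta to a hydroxy group: methoxy in place of fluoro on an aromatic carbon. Within the data shown here, no measured pair shows the size of such a swap, so no step beyond the usual scatter is expected in this assay, and another limit is likely. The expected change is a step that the limit leaves unreadable from compound 1 to compound 3. Compound 3 is estimated at 12000 nM, with an expected range from 4000 nM to 30000 nM.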

Compound 3, half-maximal inhibitory concentration: > 10000 nM
Compound 3 was reported as a limit (the forecaster's own chance of this, stated with the estimate: 75%); the middle value is on the limit's open side.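

No step can be read between compound 1 and compound 3, because both stop at the same limit, not a number: the limit of > 10000 nM in this assay, at which 2 of the 3 values shown sit.

As far as these compounds go, whether methoxy in place of fluoro on an aromatic carbon changes activity on the shared core at all stays open.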